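The source may hold more compounds than are shown below. What is called first, only, known or untested is meant among the compounds shown, and "the series" means these compounds.

In a physicochemical assay for solubility, using the shake flask method, in simulated intestinal fluid, measured as kinetic solubility, with a stated time of 20 h, at pH 6.5 (on this read-out lower numbers stand for lower solubility and higher numbers for higher solubility), compound 1 `Fc1ccc(Nc2cc3[nH]c(-c4ccc(F)c(F)c4)nc3cn2)nc1` gives >= 50000 nM as a limit of the assay, not a number. Compound 2 `FC(F)(F)c1cccc(-c2nc3cnc(Nc4ccc(-c5nnn[nH]5)cn4)cc3[nH]2)c1` gives < 5000 nM as a limit of the assay too. For the measured compounds named here, compound 3 `FC(F)(F)c1ccc(Nc2cc3[nH]c(C4CCCC4)nc3cn2)nc1` gives 85000 nM as the only actual number among the three results so far. The change to compound 4 `FC(F)(F)c1ccc(Nc2cc3[nH]c(CC4CC4)nc3cn2)nc1` is counted as cyclopropylmethyl in place of cyclopentyl on an aromatic carbon and puts cyclopropylmethyl in place of cyclopentyl on an aromatic carbon. Going by the values given here, no measured pair shows what such a change does, so no step beyond the scatter is expected in either direction in this assay for this pair. The expected change is small, a 1.1-fold higher number from compound 3 to compound 4 (0.02 log units; within the scatter) in size. Compound 4 is estimated at 90000 nM with 40000 nM to 200000 nM as the expected range.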

Compound 4, solubility: 156000 nM
For compound 4 the middle estimate is 1.7-fold (0.24 log units) below the measured one; the range from low to high includes it.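

In this assay, for the compounds shown here, cyclopropylmethyl in place of cyclopentyl on an aromatic carbon between two ring nitrogen atoms gives a 1.8-fold higher number from compound 3 to compound 4 (0.26 log units; within the scatter) in the first pair that differs only in this place. So at this position, one carbon-only group with a non-aromatic ring can stand in for the other without a step beyond the scatter. No measurement shown here gives a cause for this result. From the compounds shown here alone, what an amine, a carboxylic acid or a longer chain would do in this place stays open.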